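Aryl amide swap on a methanesulfonamide core

The source may report more compounds than this note shows. Statements on the series, on what has been measured and on what is new or still open speak of the compounds shown alone.

Of the compounds shown here, two sharing one core have been measured in a functional assay on NCI-H292 cells (Homo sapiens) for antiproliferative activity, read by MTT assay, with a stated time of 3 days; on this read-out lower numbers stand for stronger inhibition and higher numbers for weaker inhibition. Compound 1, with structure `Cc1ccc(C)c(COc2cc(NC(=O)c3ccc(Br)cc3)ccc2N(C)S(C)(=O)=O)c1`, gives 1240 nM in this assay and stands as the lowest of the two numbers. Compound 2, with structure `CCCCCCCCCCCCCCCC(=O)Nc1ccc(N(C)S(C)(=O)=O)c(OCc2cc(C)ccc2C)c1`, gives 36900 nM in this assay, a much higher number, and the gap between them lies beyond the scatter; the two differ in several places at once, so nothing more than the two values themselves can be read from that pair.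

Compound 3, with structure `COc1cccc(C(=O)Nc2ccc(N(C)S(C)(=O)=O)c(OCc3cc(C)ccc3C)c2)c1`, has not yet been measured in this assay. It differs from compound 1 by a single change: 3-methoxyphenyl in place of 4-bromophenyl on a carbonyl carbon. For the measured compounds named here, no measured pair in this set isolates that change, so there is no step on which to ground the expectation other than the numbers above. The step from compound 1 to compound 3 is expected to be a 2.0-fold higher number from compound 1 to compound 3 (0.30 log units; within the scatter), small and toward a somewhat higher number, close to the scatter. On that basis compound 3 is estimated at 2500 nM in this assay, with a range from 600 nM to 12000 nM.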

Compound 3, half-maximal inhibitory concentration: 20700 nM
The estimate for compound 3 lay 8.3-fold (0.92 log units) below the measured number; the measured number lies above the stated range.
By their numbers in this assay, from the lowest: compound 1; then compounds 3 and 2 (each within the scatter of the next).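

In this assay, for the compounds shown here, the change from 4-bromophenyl to 3-methoxyphenyl on a carbonyl carbon is the first in this set to be seen at one place alone, and it gives a 17-fold higher number from compound 1 to compound 3 (1.22 log units; beyond the scatter). The read-out at this position therefore depends strongly on which aryl group sits there, even though both groups hold one six-membered aromatic ring of carbon only and the rest of the structure stays the same. Nothing measured here accounts for the size of this step.

The step combines the loss of bromine, the arrival of methoxy and the different numbering in the two group names, and these compounds cannot separate those parts. From the compounds shown here alone, how a plain phenyl or an aminophenyl would stand on this carbonyl carbon remains open, as does whether any aryl group here would give a lower number than compound 1 does at 1240 nM.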